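A few compounds are considered here, and "the series" means these few. Any claim that something is new, unique, unknown or untested is made for them only; others in the source may bear on it.

Measured compounds:
compound 1, `Cc1ccc(Nc2cncc(N3CC4CC(C3)N4)c2)cc1`: 0.148 nM
compound 2, `Fc1ccc(Nc2cncc(N3CC4CC(C3)N4)c2)cc1`: 0.091 nM
compound 3, `Cc1ccc(Nc2ccc(N3CC4CC(C3)N4)cn2)cc1`: 52.1 nM

All three values come from an assay on cell membranes for displacement of a labelled ligand from Neuronal acetylcholine receptor; alpha4/beta2 (Rattus norvegicus); on this read-out lower numbers stand for stronger inhibition and higher numbers for weaker inhibition. Compound 1 and compound 2 share one core and differ only by fluoro in place of methyl on an aromatic carbon; this change gave a 1.6-fold lower number from compound 1 to compound 2 (0.21 log units; within the scatter), so the two stand within the scatter of each other. Compound 3 is built from the same atoms as compound 1 joined differently; the difference between the two cores is not broken down here. Its value in this assay sits far beyond the scatter from both compound 1 and compound 2, the highest number of the three.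

Compound 4, `Fc1ccc(Nc2ccc(N3CC4CC(C3)N4)cn2)cc1`, is the counterpart of compound 3 carrying the change (fluoro in place of methyl on an aromatic carbon). The surroundings of the change match those of the step from compound 1 to compound 2 word for word, so this is the same change made on the core of compound 3. The expected step is a 1.5-fold lower number from compound 3 to compound 4 (0.17 log units; within the scatter), resting on the measured step from compound 1 to compound 2, a 1.6-fold lower number from compound 1 to compound 2 (0.21 log units; within the scatter), which stayed within the scatter. Compound 4 is therefore expected to give about 35 nM in this assay, with a range from 12 nM to 110 nM.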

Compound 4, inhibition constant: 2.38 nM
Estimate against measurement, compound 4: 15-fold (1.17 log units) above; the measured number lies below the stated range.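

In this assay, the change from 4-methylphenyl to 4-fluorophenyl does not carry over as a constant step between the two cores: the same change on two cores in this assay, a 1.6-fold lower number (0.21 log units; within the scatter) from compound 1 to compound 2 and a 22-fold lower number (1.34 log units; beyond the scatter) from compound 3 to compound 4, 13-fold (1.13 log units) apart, beyond the scatter of two such steps. On the core of compound 3 the change gives a 22-fold lower number from compound 3 to compound 4 (1.34 log units; beyond the scatter), a large step, whereas on the core of compound 1 it stays within the scatter, so an estimate transferred from one of these cores to the other would not have been reliable here. This shows that the size of the step depended on the core in these two pairs, but it does not show what in the cores sets the difference, and two pairs give no rule for any further core.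

Open, from the compounds shown here alone, is whether other groups on the same aromatic carbon, such as chloro, methoxy, nitrile or an amine, would also give steps that differ between the two cores. Also open, going by these compounds, is whether the difference between the steps holds for the same change on the receptors of other assays.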